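The source may hold more compounds than are shown below. What is called first, only, known or untested is meant among the compounds shown, and "the series" means these compounds.

Measured so far in a functional assay on HCT-116 cells (Homo sapiens) for antiproliferative activity, read by MTT assay, with a stated time of 72 h; a higher number here means a weaker inhibitor, a lower number a stronger inhibitor:
Compound 1 `O=C(CCc1cccc2c1B(O)OC2)Nc1cccc(-c2ccc(Cl)cc2)c1` gives 380 nM
Compound 2 `O=C(CCc1cccc2c1B(O)OC2)Nc1cccc(-c2cccc(C(F)(F)F)c2)c1` gives 580 nM
Compound 3 `N#Cc1cccc(-c2cccc(NC(=O)CCc3cccc4c3B(O)OC4)c2)c1` gives 140 nM

Compound 3 holds the lowest number of the three, with a 2.7-fold lower number from compound 1 to compound 3 (0.43 log units; beyond the scatter) and a 4.1-fold lower number from compound 2 to compound 3 (0.62 log units; beyond the scatter) leading to it. Compound 4 `N#Cc1ccc(-c2cccc(NC(=O)CCc3cccc4c3B(O)OC4)c2)cc1` differs from it by 4-cyanophenyl in place of 3-cyanophenyl on an aromatic carbon, which is 4-cyanophenyl in place of 3-cyanophenyl on an aromatic carbon. Going by the values given here, no measured step moves the nitrile alone. Those two steps change the group itself, so they guide this move only loosely, and a 1.5-fold higher number from compound 1 to compound 2 (0.18 log units; within the scatter) stays small. In this assay a small rise within the scatter is therefore expected, namely a 1.4-fold higher number from compound 3 to compound 4 (0.15 log units; within the scatter) as the estimated step. Compound 4 is estimated at 200 nM, with an expected range from 90 nM to 450 nM as its limits.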

Compound 4, half-maximal inhibitory concentration: 410 nM
Estimate against measurement, compound 4: 2.1-fold (0.31 log units) below, and the stated range covers the measured number.
By their numbers in this assay, from the lowest: compound 3; then compounds 1, 4 and 2 (each within the scatter of the next).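

In this assay the nitrile's place on the ring matters by itself, with the same atoms joined differently: there is a 2.9-fold higher number from compound 3 to compound 4 (0.47 log units; beyond the scatter). Moved in this way, the nitrile no longer sets the compound apart from the chloro or trifluoromethyl compounds, with a 1.1-fold higher number from compound 1 to compound 4 (0.03 log units; within the scatter) and a 1.4-fold lower number from compound 2 to compound 4 (0.15 log units; within the scatter). Nothing given here explains the gap between the 3-cyanophenyl and 4-cyanophenyl compounds. From the compounds shown here alone, whether an amine or a carboxylic acid on that ring would match compound 3 remains open. So does whether the gap between these two placements holds for a methoxy group.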